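From Propargyl Ether to Free Oxime on a Shared Core

The source may hold more compounds than are shown below. What is called first, only, known or untested is meant among the compounds shown, and "the series" means these compounds.

compound 1, `C#CCO/N=C/c1c(-c2ccc(C)cc2)nc2c(C)cccn12`: 40 mg/kg
compound 2, `COc1ccc(Cn2cc(CO/N=C/c3c(-c4ccccc4)nc4c(C)cccn34)nn2)cc1`: 40 mg/kg
compound 3, `C#CCO/N=C/c1c(-c2ccc(C)cc2)nc2ccc(Br)cn12`: 20 mg/kg

Of the compounds shown here, three built on a shared core have been tested in a functional assay on the whole organism (strain NMRI) with Mus musculus as the target, in the maximal electroshock model, with a stated time of 4 h; on this read-out higher numbers stand for an effect only at larger amounts of compound and lower numbers for an effect already at smaller amounts. Compound 1 gives 40 mg/kg, compound 2 gives 40 mg/kg, and compound 3 gives 20 mg/kg. Compound 3 carries the lowest of the three numbers, yet its gap to compound 1 and to compound 2 lies within the scatter of repeated measurements, so no order among the three can be read from these values.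

Compound 4 `Cc1ccc(-c2nc3ccc(Br)cn3c2/C=N/O)cc1` differs from compound 3 in one place: hydrogen in place of propargyl on an oxygen. Cut one bond further out, the same difference reads propargyloxy to hydroxy. Going by the values given here, no pair of measured compounds shows this change, so its size cannot be taken from the numbers at hand. The step of a 1.5-fold higher number from compound 3 to compound 4 (0.18 log units; within the scatter) is therefore expected to stay within the scatter, with a slight lean toward a higher number. Compound 4 is estimated to give 30 mg/kg, within a range from 10 mg/kg to 100 mg/kg.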

Compound 4, minimum effective dose: 100 mg/kg
The estimate for compound 4 lay 3.3-fold (0.52 log units) below the measured number; low and high end bracket the measured number.
By their numbers in this assay, from the lowest: compounds 3, 1 and 2 (each within the scatter of the next); then compound 4.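

In this assay, going by these compounds alone, replacing propargyl with hydrogen on an oxygen whose other neighbours are a double-bonded nitrogen gives a 5.0-fold higher number from compound 3 to compound 4 (0.70 log units; beyond the scatter), the only step between compounds differing in one place. Within the data shown here, this shows that the group on this oxygen can shift the read-out beyond the scatter, which the earlier compounds, with no such pair among them, could not show: going from propargyloxy to hydroxy here means that an effect appears only at larger amounts of compound. No measured evidence bears on why the step arises. This single pair leaves open whether the same change would have a similar size on the core of compound 1. It also leaves open whether a methyl or a longer alkyl chain on this oxygen would stay closer to compound 3 or to compound 4.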